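From 3,4-dichlorophenyl to 2,3-dichlorophenyl in a small series

This account rests on a few compounds, and the source may have more. Where it says the series, first, only, none or still open, it means among the compounds named here.

Among the measured compounds shown here, in a functional assay on A549 cells (Homo sapiens) for antiproliferative activity, read by MTT assay, with a stated time of 72 h (a higher number here means a weaker inhibitor, a lower number a stronger inhibitor), compound 1 (`NC1=NC2(CCSCC2)N(OCCCOc2ccc(Cl)c(Cl)c2)C(N)=N1`) gives 1 nM as the lower of the two numbers measured so far. In this assay compound 2 (`NC1=NC2(CCOCC2)N(OCCCOc2cccc(Cl)c2Cl)C(N)=N1`) gives 100 nM and that gap lies beyond the usual scatter. Compound 3 (`NC1=NC2(CCSCC2)N(OCCCOc2cccc(Cl)c2Cl)C(N)=N1`) departs from compound 1 in one place, with 2,3-dichlorophenyl in place of 3,4-dichlorophenyl on an oxygen on a saturated carbon. For the measured compounds named here, no measured pair isolates this change, so its size cannot be read directly. Compound 2, which also carries 2,3-dichlorophenyl, stands at 100 nM and this value points to a rise in this assay, with only part of that gap expected here. The expected move, beyond the scatter and toward weaker inhibition, is a 10-fold higher number from compound 1 to compound 3 (1.00 log units; beyond the scatter) as a moderate step. For compound 3 the estimated value is 10 nM with an expected range from 2 nM to 60 nM in this measurement.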

Compound 3, half-maximal inhibitory concentration: 1 nM
Compound 3: middle estimate off by 10-fold (1.00 log units), on the high side; the whole stated range lies above it.
By their numbers in this assay, from the lowest: compounds 1 and 3 (each within the scatter of the next); then compound 2.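

In this assay, moving the two chlorines from 3,4-dichlorophenyl to 2,3-dichlorophenyl on the oxygen leaves the activity in place, with no change at the digits printed from compound 1 to compound 3 (within the scatter). Among the compounds shown here, the earlier compounds could not show this, since the only compound with 2,3-dichlorophenyl was compound 2, which gives 100 nM. Compound 3 carries the same 2,3-dichlorophenyl group and gives 1 nM, so the value of compound 2 cannot be read as a mark of that group, and it goes with the other place in which the core of compound 2 differs. Nothing shown here gives a reason for this result.

The compounds shown leave open whether this tolerance extends to a phenyl with a single chlorine, or to a trifluoromethyl or methoxy group in place of chlorine. They also leave open how a longer chain to the oxygen would read.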